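A Second Methoxy on the Amide Aryl Ring

This account rests on a few compounds, and the source may have more. Where it says the series, first, only, none or still open, it means among the compounds named here.

compound 1 `CC(=O)Nc1ccc(Cc2noc(CCC(=O)Nc3ccccc3)n2)cc1`: 34.2%
compound 2 `COc1ccc(NC(=O)CCc2nc(Cc3ccc(NC(C)=O)cc3)no2)cc1`: 49.3%
compound 3 `CC(=O)Nc1ccc(Cc2noc(CCC(=O)Nc3ccc(F)cc3F)n2)cc1`: 52.1%

These three compounds share one core and differ only in the aryl group on the amide nitrogen. In a functional assay on the whole organism (strain C57BL/6) for inhibition, with Mus musculus as the target, read by paw edema, with stated times of 1 h and 4 h, at a dose of 100 mg/kg by the oral route (a lower number here means less inhibition, a higher number more inhibition at the dose given (going by the name of the read-out)), compound 3 has the largest of the three numbers: the step of a number 17.9 percentage points higher from compound 1 to compound 3 (beyond the scatter) is beyond the scatter, while the step of a number 2.8 percentage points higher from compound 2 to compound 3 (within the scatter) is within it, so compound 3 and compound 2 cannot be ordered against each other. Compound 4 `COc1ccc(NC(=O)CCc2nc(Cc3ccc(NC(C)=O)cc3)no2)cc1OC` is not yet measured. Its change from compound 3 is 3,4-dimethoxyphenyl in place of 2,4-difluorophenyl on an amide-type nitrogen. Among the compounds with values here, two measured steps bear on it. The step of a number 15.1 percentage points higher from compound 1 to compound 2 (beyond the scatter) shows a modest gain when one methoxy enters, and the step of a number 2.8 percentage points higher from compound 2 to compound 3 (within the scatter) shows that a methoxy-bearing ring and a fluorine-bearing ring give numbers within the scatter of each other. Within the data shown here, no measured step covers a second methoxy. Returning to a methoxy-bearing ring is therefore expected to leave the number near where compound 3 stands, so the step of a number 0.1 percentage points lower from compound 3 to compound 4 (within the scatter) is expected to stay within the scatter. The estimate for compound 4 in this assay is 52%, in the range 38% to 66%.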

Compound 4, a percentage reported as inhibition, in the whole organism at one dose (the size of the read-out at that dose, not a potency): 95.9%
Estimate against measurement, compound 4: 43.9 percentage points below; measured number above the stated range.
By their numbers in this assay, from the lowest: compound 1; then compounds 2 and 3 (each within the scatter of the next); then compound 4.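

On the aryl ring at the amide nitrogen, a second methoxy does far more than the first: in this assay there is a number 46.6 percentage points higher from compound 2 to compound 4 (beyond the scatter) when it enters, against a number 15.1 percentage points higher from compound 1 to compound 2 (beyond the scatter) when the first one enters. Changing the whole ring gives a number 43.8 percentage points higher from compound 3 to compound 4 (beyond the scatter) for 3,4-dimethoxyphenyl in place of 2,4-difluorophenyl and a number 61.7 percentage points higher from compound 1 to compound 4 (beyond the scatter) for 3,4-dimethoxyphenyl in place of phenyl, so this position can move the number much further than compound 1, compound 2 and compound 3 had shown. Nothing available explains an effect of this size.

The compounds shown leave open whether the added methoxy would give the same result on its own, without the first one. They also leave open whether an ethoxy, a hydroxyl or an amine on this ring would keep the number this high.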